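The source may hold more compounds than are shown below. What is called first, only, known or untested is meant among the compounds shown, and "the series" means these compounds.

Two compounds of a shared core, which differ only in the length of a saturated chain, have been tested in an ADME assay on PANC-1 cells (Homo sapiens) for cytotoxicity, read by sulforhodamine B assay, with a stated time of 48 h, tested at 10 uM; a lower number here means less inhibition, a higher number more inhibition at the concentration tested (going by the name of the read-out). Compound 1 `CCCCCCc1cn(C(c2ccccc2)c2cc3cc(Br)ccc3nc2OC)nn1` gives 6.08% in this assay. Compound 2 `CCCCCCCCc1cn(C(c2ccccc2)c2cc3cc(Br)ccc3nc2OC)nn1` gives 12.1% in this assay, and this is the higher of the two numbers, though the step of a number 6 percentage points higher from compound 1 to compound 2 (within the scatter) is within the scatter, so the two compounds cannot be told apart on these data. Compound 3 `CCCCCc1cn(C(c2ccccc2)c2cc3cc(Br)ccc3nc2OC)nn1` is not yet measured. It differs from compound 2 in one place: hydrogen in place of propyl on a saturated chain carbon, five bonds along the chain from an aromatic carbon. Within the data shown here, the only step that bears on this is the one from compound 1 to compound 2, which also changed the length of the same chain and stayed within the scatter. A shortening of the chain is therefore expected to give a step no larger than the scatter, a number 6.1 percentage points lower from compound 2 to compound 3 (within the scatter). Compound 3 is estimated at 6%, with a range from -4% to 16%.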

Compound 3, a percentage reported as inhibition, at one concentration (the size of the read-out at that concentration, not a potency): 5.07%
Compound 3: the middle estimate sits 0.9 percentage points above what was measured; low and high end bracket the measured number.
By their numbers in this assay, from the lowest: compounds 3, 1 and 2 (each within the scatter of the next).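

At this position, the saturated chain now has three lengths to compare. Hydrogen in place of propyl gives a number 7 percentage points lower from compound 2 to compound 3 (within the scatter), and hydrogen in place of methyl gives a number 1 percentage points lower from compound 1 to compound 3 (within the scatter). All three pairs therefore lie within the scatter in this assay, so among these compounds the length of the chain does not separate one from another, and no trend with length can be read. Nothing available here offers an explanation for these numbers.

A much shorter chain such as methyl, a longer chain, or a chain ending in an amine or a carboxylic acid could still read differently at this position. Each number also comes from a single concentration, so the compounds shown say nothing about potency.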